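The source may hold more compounds than are shown below. What is called first, only, known or untested is meant among the compounds shown, and "the series" means these compounds.

In a functional assay on MCF7 cells (Homo sapiens) for antiproliferative activity, read by MTT assay, with a stated time of 48 h (a lower number here means a stronger inhibitor, a higher number a weaker inhibitor), compound 1 (`Cc1cc2nc(NC(c3cn(-c4ccccc4)nc3-c3ccc([N+](=O)[O-])cc3)c3c(O)ccc4ccccc34)sc2cc1C`) gives 41100 nM and compound 2 (`COc1cccc(-c2nn(-c3ccccc3)cc2C(Nc2nc3ccccc3s2)c2c(O)ccc3ccccc23)c1`) gives 16900 nM as the lower of the two numbers, a gap that lies beyond the usual scatter. These two compounds differ in more than one place, so their gap cannot be tied to any single change. Compound 3 (`Oc1ccc2ccccc2c1C(Nc1nc2ccccc2s1)c1cn(-c2ccccc2)nc1-c1cccc(Cl)c1`) has not yet been measured. Its change from compound 2 is chloro in place of methoxy on an aromatic carbon in one place: chloro in place of methoxy on an aromatic carbon, so that 3-methoxyphenyl becomes 3-chlorophenyl. Going by the values given here, no measured pair here shows this swap, and the data therefore give no direct guide to its size or direction. The shared core stays untouched, so the best starting point is compound 2 at 16900 nM and only a small shift is expected in this assay with no firm direction. The estimated step is a 1.2-fold lower number from compound 2 to compound 3 (0.08 log units; within the scatter) and stays within the scatter. For compound 3 the expected value is 14000 nM with an estimated range from 6000 nM to 35000 nM around it.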

Compound 3, half-maximal inhibitory concentration: 20700 nM
Compound 3: the middle estimate sits 1.5-fold (0.17 log units) below what was measured; measured number inside the range.
By their numbers in this assay, from the lowest: compounds 2, 3 and 1 (each within the scatter of the next, the first and the last beyond it).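

In this assay, replacing methoxy with chloro on the aromatic carbon meta to a large group gives a 1.2-fold higher number from compound 2 to compound 3 (0.09 log units; within the scatter). Going by these compounds alone, this is the first direct reading of this change, and it shows that 3-methoxyphenyl and 3-chlorophenyl cannot be told apart here, even though the swap exchanges a two-atom group carrying a hydrogen-bond acceptor for a single chlorine atom with none. Nothing measured on these compounds explains why the two groups read alike.

One swap cannot show whether this position is indifferent to its substituent in general, and an amine, a carboxylic acid or a longer chain in the same place might give quite a different number. As far as these compounds go, compound 1 differs from the other two compounds in more than one place, so it cannot settle how much this position matters, and the effect of the same swap on another version of the core also remains open.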